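The source may hold more compounds than are shown below. What is called first, only, known or untested is meant among the compounds shown, and "the series" means these compounds.

Compound 1 `CCN(CC)c1ccc2cc(C(=O)c3ccc(N4CCN(C(=O)CN5CCN(S(=O)(=O)C6CC6)CC5)CC4)cc3)oc2c1`: in a functional assay on MCF7 cells (Homo sapiens) for cytotoxicity, read by MTT assay, with a stated time of 48 h (a lower number here means a stronger inhibitor, a higher number a weaker inhibitor), compound 1 gives > 40000 nM, which is a limit of the assay rather than a number.
Compound 2 `CCN(CC)c1ccc2cc(C(=O)c3ccc(N4CCN(C(=O)CN5CCN(S(=O)(=O)c6ccc(C(F)(F)F)cc6)CC5)CC4)cc3)oc2c1`: in this assay compound 2 gives 17500 nM.
Compound 3 `CCN(CC)c1ccc2cc(C(=O)c3ccc(N4CCN(C(=O)CN5CCN(S(=O)(=O)c6ccc(F)cc6)CC5)CC4)cc3)oc2c1`: in this assay compound 3 gives 20500 nM.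

Compound 1 thus stands only at the limit of > 40000 nM in this assay, at which 1 of the 3 values shown sits, with no number of its own. Compound 4 `CCN(CC)c1ccc2cc(C(=O)c3ccc(N4CCN(C(=O)CN5CCN(Cc6ccc(F)c(F)c6)CC5)CC4)cc3)oc2c1` differs from it by 3,4-difluorobenzyl in place of cyclopropylsulfonyl on an amine nitrogen in a ring. The measured steps that bear on this change are the two other replacements of the cyclopropyl: an at least 2.2-fold lower number from compound 1 to compound 2 (0.35 log units; beyond the scatter) and an at least 1.9-fold lower number from compound 1 to compound 3 (0.29 log units; that floor lies within the scatter), both running toward lower numbers, whereas a 1.2-fold higher number from compound 2 to compound 3 (0.07 log units; within the scatter). Among the measured compounds shown here, the change to compound 4 also removes the sulfonyl, for which no measured step exists. In this assay a modest lowering is expected for compound 4, an at least 2.0-fold lower number from compound 1 to compound 4 (0.30 log units; that floor lies within the scatter). Compound 4 is estimated at 20000 nM, within 7000 nM to 60000 nM.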

Compound 4, half-maximal inhibitory concentration: 9220 nM
Compound 4: middle estimate off by 2.2-fold (0.34 log units), on the high side, within the range that was stated.
By their numbers in this assay, from the lowest: compounds 4, 2 and 3 (each within the scatter of the next, the first and the last beyond it). At a limit, above all of these: compound 1.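

In this assay, the ring nitrogen does not need a sulfonyl to give a measurable number: 3,4-difluorobenzyl in place of cyclopropylsulfonyl gives an at least 4.3-fold lower number from compound 1 to compound 4 (0.63 log units; beyond the scatter). Replacing (4-fluorophenyl)sulfonyl gives a 2.2-fold lower number from compound 3 to compound 4 (0.35 log units; beyond the scatter), a modest step with a number at both ends, although compound 2 stays within the scatter of compound 4. The step from compound 1 is only a floor: the limit of > 40000 nM in this assay, at which 1 of the 4 values shown sits.

An unsubstituted benzyl or a 4-fluorobenzyl on this nitrogen would separate the share of the fluorines from that of the benzyl itself. On these data alone, what an acetyl or a methyl would give there remains open.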